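Removing the chlorobenzyl arm from a weak thiazolidinedione

The source may report more compounds than this note shows. Statements on the series, on what has been measured and on what is new or still open speak of the compounds shown alone.

Measured so far:
compound 1 `Nc1ccc(/C=C2\SC(=O)N(Cc3ccc(Cl)cc3)C2=O)cc1` — 87000 nM
compound 2 `C=C(Br)C(=O)Nc1ccc(/C=C2\SC(=O)N(CC)C2=O)cc1` — 870 nM

Compound 1 carries a free aniline on its benzylidene side and a 4-chlorophenyl on the saturated chain carbon bound to the amide-type nitrogen in the ring. In a functional assay on CCRF-CEM cells (Homo sapiens) for cytotoxicity, read by cell counting, with a stated time of 3 days (a lower number here means a stronger inhibitor, a higher number a weaker inhibitor), compound 1 gives 87000 nM, the higher of the two numbers recorded here. Compound 2 differs from compound 1 in several places. In this assay compound 2 gives 870 nM. The two values are far apart, well beyond the scatter, but since the compounds differ in several places no single change can be read from this pair.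

Compound 3 `CN1C(=O)S/C(=C\c2ccc(N)cc2)C1=O` is the unmeasured analogue. Relative to compound 1 the change is hydrogen in place of 4-chlorophenyl on a saturated chain carbon bound to an amide-type nitrogen in a ring. Going by the values given here, no pair of measured compounds isolates this change, so the expectation rests on compound 1 alone. The step from compound 1 to compound 3 is expected to be small, most likely none beyond the scatter, with any shift tending toward a higher number; the expected step is a 1.4-fold higher number from compound 1 to compound 3 (0.14 log units; within the scatter). Compound 3 is therefore estimated at 120000 nM, within a range of 35000 nM to 400000 nM in this assay.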

Compound 3, half-maximal inhibitory concentration: 62000 nM
The estimate for compound 3 lay 1.9-fold (0.29 log units) above the measured number, and the stated range covers the measured number.
By their numbers in this assay, from the lowest: compound 2; then compounds 3 and 1 (each within the scatter of the next).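

In this assay, hydrogen in place of 4-chlorophenyl on a saturated chain carbon bound to an amide-type nitrogen in a ring gives a 1.4-fold lower number from compound 1 to compound 3 (0.15 log units; within the scatter), a step within the scatter. With the free aniline kept in both compounds, a group of 7 heavy atoms, including one six-membered aromatic ring of carbon only, can therefore leave this position with no shift that can be told apart from repeat-measurement noise, something the earlier pair could not show because its members differ in several places. Nothing given here accounts for this outcome.

Going by these compounds alone, the result describes only this one exchange, so it leaves open whether a different group at the same place, such as a carboxylic acid, a primary amine or a longer chain like n-butyl, would move the number beyond the scatter. It also leaves unresolved what separates compound 2 from the others, since compound 2 differs from both compound 1 and compound 3 in more than one place and no single change can be read from either pair.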